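This account rests on a few compounds, and the source may have more. Where it says the series, first, only, none or still open, it means among the compounds named here.

Measured so far: compound 1 `Cc1nc(-c2ccc(Cl)cc2)sc1C1SCC(=O)N1c1ccc(F)c(Cl)c1` with 53.4% and compound 2 `Cc1nc(-c2ccccc2)sc1C1SCC(=O)N1c1ccc(F)c(Cl)c1` with 55.9% in a functional assay on the whole organism (strain Wistar albino) for inhibition, with Rattus norvegicus as the target, read by paw edema, with a stated time of 1 h, at a dose of 40 mg/kg by the oral route; a higher number here means more inhibition at the dose given (going by the name of the read-out), a lower number less inhibition.

Compound 1 stands lowest of the two numbers, but the only measured step, a number 2.5 percentage points higher from compound 1 to compound 2 (within the scatter), lies within the scatter, so no order between them is shown. Compound 3 `Cc1ccc(N2C(=O)CSC2c2sc(-c3ccc(Cl)cc3)nc2C)cc1` differs from compound 1 at another place: 4-methylphenyl in place of 3-chloro-4-fluorophenyl on an amide-type nitrogen in a ring. Among the measured compounds shown here, no measured step touches the group on the amide-type nitrogen, so the one known step does not bear on it, and nothing beyond the scatter is expected in either direction. Compound 3 is expected to give 50%, between 35% and 65%, an expected step of a number 3.4 percentage points lower from compound 1 to compound 3 (within the scatter).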

Compound 3, a percentage reported as inhibition, in the whole organism at one dose (the size of the read-out at that dose, not a potency): 38.3%
The estimate for compound 3 lay 11.7 percentage points above the measured number; the range from low to high includes it.
By their numbers in this assay, from the lowest: compound 3; then compounds 1 and 2 (each within the scatter of the next).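

In this assay putting 4-methylphenyl in place of 3-chloro-4-fluorophenyl on the amide-type nitrogen gives a number 15.1 percentage points lower from compound 1 to compound 3 (beyond the scatter) and so shows that this position, unlike the chloro change measured earlier, can move the read-out past the usual scatter. Both groups keep one six-membered aromatic ring of carbon only, so the step goes with what that ring carries. No evidence is available on why the number falls. Because this one step changes chloro, fluoro and methyl together, it leaves open which of them matters. Also open, on these data alone, is how an amine or a carboxylic acid on that ring would read, and whether the step holds on the core of compound 2.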